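The source may hold more compounds than are shown below. What is called first, only, known or untested is meant among the compounds shown, and "the series" means these compounds.

Compounds measured so far:
compound 1, `O=C(C1CCC1)N1CCc2nc(C#Cc3ccccc3)sc2C1`: 370 nM
compound 2, `CC1CCC(C(=O)N2CCc3nc(C#Cc4ccccc4)sc3C2)CC1`: a limit, > 10000 nM
compound 3, `Cc1cccc(C(=O)N2CCc3nc(C#Cc4ccccc4)sc3C2)n1`: a limit, > 10000 nM

Among the measured compounds shown here, in an assay on HEK293 cells for negative allosteric modulation of metabotropic glutamate receptor 5 (Homo sapiens), read by FLIPR, with a stated time of 1 h (a higher number here means a weaker inhibitor, a lower number a stronger inhibitor), compound 1 gives 370 nM, and this is the only number among the three values shown. Compound 2 is reported only as a limit, > 10000 nM. Compound 3 likewise is reported only as a limit, > 10000 nM. The two measured steps away from compound 1 therefore both run to the limit of > 10000 nM in this assay, at which 2 of the 3 values shown sit: an at least 27-fold higher number from compound 1 to compound 2 (1.43 log units; beyond the scatter), and an at least 27-fold higher number from compound 1 to compound 3 (1.43 log units; beyond the scatter). The step between compound 2 and compound 3 is a step that the two limits leave unreadable from compound 2 to compound 3.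

Compound 4, `O=S(=O)(C1CC1)N1CCc2nc(C#Cc3ccccc3)sc2C1`, differs from compound 1 in another way: cyclopropylsulfonyl in place of cyclobutylcarbonyl on an amine nitrogen in a ring. For the measured compounds named here, the two measured steps replaced the cyclobutyl with a larger ring on the same carbonyl carbon, and both were large losses; compound 4 instead keeps a small ring but exchanges the carbonyl for a sulfonyl, a change for which no measured step exists. Those two steps bear on it only by showing that the cyclobutylcarbonyl tolerates little alteration. A weakening step is therefore expected for compound 4, a 4.1-fold higher number from compound 1 to compound 4 (0.61 log units; beyond the scatter), though smaller than the two seen. Compound 4 is estimated at 1500 nM, with a range from 400 nM to 8000 nM.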

Compound 4, half-maximal inhibitory concentration: 34 nM
Estimate against measurement, compound 4: 44-fold (1.64 log units) above; the whole stated range lies above it.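

Compound 4 shows that this place is not closed to change: where the two earlier steps away from the cyclobutylcarbonyl ended at a limit, cyclopropylsulfonyl in place of cyclobutylcarbonyl on an amine nitrogen in a ring gives an 11-fold lower number from compound 1 to compound 4 (1.04 log units; beyond the scatter) in this assay. A carbonyl is therefore not required at this place for inhibition on the shared core, and among the compounds shown the sulfonyl is the only group that gives a lower number than compound 1. The change alters two things at once, the four-membered ring for a three-membered one and the carbonyl for a sulfonyl, so the step cannot be credited to either alone.

Still open, going by these compounds, is which half of the change matters, which a pairing such as cyclobutylsulfonyl or cyclopropylcarbonyl would separate, and how a longer chain or an amine on the sulfonyl would fare. The steps that involve two limits cannot be read, so how far the larger groups fall stays unknown, and they rest on a limit of the assay and not on a number: the limit of > 10000 nM in this assay, at which 2 of the 4 values shown sit.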